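Swapping hydroxy for chloro on the sulfonamide aryl ring

The source may hold more compounds than are shown below. What is called first, only, known or untested is meant among the compounds shown, and "the series" means these compounds.

Compound 2 `O=S(=O)(Nc1ccc(-c2nc3ccccc3o2)cc1)c1ccc(O)cc1` and compound 1 `O=S(=O)(Nc1ccc(-c2nc3ccccc3o2)cc1)c1ccc(Cl)c(C(F)(F)F)c1` share one core and were both tested in an assay on cells for inhibition of HSP60/HSP10 (Homo sapiens), with a stated time of 60 min; on this read-out lower numbers stand for stronger inhibition and higher numbers for weaker inhibition. Compound 1 gives 12000 nM, while compound 2 gives 78000 nM, the highest of the two numbers and a gap to compound 1 that lies beyond the usual scatter. Compound 3 `O=S(=O)(Nc1ccc(-c2nc3ccccc3o2)cc1)c1ccc(Cl)cc1` differs from compound 2 in one place: chloro in place of hydroxy on an aromatic carbon. With chloro in place of hydroxy on an aromatic carbon, a moderate step toward a lower number is expected, a 3.1-fold lower number from compound 2 to compound 3 (0.49 log units; beyond the scatter). Compound 3 is estimated at 25000 nM, within a range from 8000 nM to 80000 nM.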

Compound 3, half-maximal inhibitory concentration: 61000 nM
The estimate for compound 3 lay 2.4-fold (0.39 log units) below the measured number, and the stated range covers the measured number.
By their numbers in this assay, from the lowest: compound 1; then compounds 3 and 2 (each within the scatter of the next).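

In this assay, chloro in place of hydroxy at this position leaves the number within the scatter (a 1.3-fold lower number from compound 2 to compound 3 (0.11 log units; within the scatter)), so 4-hydroxyphenyl and 4-chlorophenyl read alike here. The gap to compound 1 instead goes with the trifluoromethyl group, as hydrogen in its place gives a clear change (a 5.1-fold higher number from compound 1 to compound 3 (0.71 log units; beyond the scatter)). Nothing available explains either step. As far as these compounds go, whether an amine or a carboxylic acid at this position would also read like hydroxy and chloro stays open. So does whether trifluoromethyl would give the same step without the chloro.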